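Tetrahydroquinoline biphenyl amides: N-substitution step to compound 3

The source may report more compounds than this note shows. Statements on the series, on what has been measured and on what is new or still open speak of the compounds shown alone.

Measured compounds:
compound 1, `CN1CCCc2cccc(NC(=O)c3ccc(-c4ccccc4)cc3)c21`: < 6.3
compound 2, `O=C(Nc1ccc2c(c1)NCCC2)c1ccc(-c2ccccc2)cc1`: 7.7

In a functional assay for antagonist activity at transient receptor potential cation channel subfamily V member 1 (Homo sapiens), read by FLIPR and calcium flux (a higher number here means a more potent compound, by a factor of ten per unit of this negative logarithm, a lower number a less potent compound), compound 2 gives 7.7, the only number shown in the series. For compound 1 this assay gives a limit, (the limit of < 6.3 in this assay, at which 1 of the 2 values shown sits), not a number. Among the compounds with values here, no pair of measured compounds differs in one place, so no measured step is available.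

Compound 3, `CC(=O)NCCN1CCCc2ccc(NC(=O)c3ccc(-c4ccccc4)cc3)cc21`, differs from compound 2 by 2-acetamidoethyl in place of hydrogen on a nitrogen on an aromatic ring in a ring. Compound 1, the other compound with a substituent on that nitrogen, sits at the limit, but it differs from compound 2 in more than one place, so its value cannot be read as a step.

A step downward beyond the scatter is expected for a number 0.70 log units lower from compound 2 to compound 3 (beyond the scatter). Compound 3 is estimated at 7, within 6.1 to 7.8.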

Compound 3, negative logarithm of the antagonist equilibrium constant: 6.9
The estimate for compound 3 lay 0.10 log units above the measured number; low and high end bracket the measured number.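

In this assay, the nitrogen on an aromatic ring in the six-membered non-aromatic ring now has its first readable step: with the rest of the core unchanged, 2-acetamidoethyl in place of hydrogen gives a number 0.80 log units lower from compound 2 to compound 3 (beyond the scatter) on that position. The substituted compound 3 still gives a number, 6.9, so this nitrogen carries 2-acetamidoethyl with a modest loss in this series. Nothing shown here bears on the reason for this step.

One substituent on this nitrogen cannot separate the effect of the chain from that of its acetamide end. A plain ethyl chain, a longer chain, or a 2-aminoethyl or carboxylic acid-bearing chain at the same place would show whether the step follows the chain or its end group.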